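Swapping the amide arm on a shared pyrazole-free core

This account rests on a few compounds, and the source may have more. Where it says the series, first, only, none or still open, it means among the compounds named here.

Compound 1 `CNC(=O)c1cc(C)n(Cc2cc(Cl)ccc2OCc2ccccc2)n1`: 100 nM
Compound 2 `Cc1cc(C(=O)Nc2ccc(F)cc2)nn1Cc1cc(Cl)ccc1OCc1ccccc1`: 79.4 nM
Compound 3 `CC(=O)Nc1cc(C)n(Cc2cc(Cl)ccc2OCc2ccccc2)n1`: 316 nM

These three compounds share one core and were tested in an assay on CHO-K1 cells for displacement of a labelled ligand from prostaglandin E2 receptor EP1 subtype (Homo sapiens); on this read-out lower numbers stand for stronger inhibition and higher numbers for weaker inhibition. Compound 1 stands second highest of the three numbers; compound 2 lies nearest, a 1.3-fold lower number from compound 1 to compound 2 (0.10 log units; within the scatter), while compound 3 lies furthest, a 3.2-fold higher number from compound 1 to compound 3 (0.50 log units; beyond the scatter).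

Compound 4 `Cc1cc(NC(=O)CC(C)(C)C)nn1Cc1cc(Cl)ccc1OCc1ccccc1` has not yet been measured. It differs from compound 1 in one place: (neopentylcarbonyl)amino in place of methylcarbamoyl on an aromatic carbon.

Within the data shown here, two measured steps bear on this. Replacing methylcarbamoyl with acetamido on an aromatic carbon gave a 3.2-fold higher number from compound 1 to compound 3 (0.50 log units; beyond the scatter), and replacing (4-fluorophenyl)carbamoyl with acetamido gave a 4.0-fold higher number from compound 2 to compound 3 (0.60 log units; beyond the scatter). Within the carbamoyl pair, 4-fluorophenyl in place of methyl gave only a 1.3-fold lower number from compound 1 to compound 2 (0.10 log units; within the scatter), so enlarging the chain changed little there. Among the measured compounds shown here, compound 4 carries an amino-type group like compound 3, but with a longer chain, and no measured step shows what that chain adds.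

The expectation is therefore a higher number, a modest step, a 2.5-fold higher number from compound 1 to compound 4 (0.40 log units; beyond the scatter). Compound 4 is estimated at 250 nM, with a range from 80 nM to 800 nM.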

Compound 4, half-maximal inhibitory concentration: 10 nM
Compound 4: the middle estimate sits 25-fold (1.40 log units) above what was measured; the whole stated range lies above it.
By their numbers in this assay, from the lowest: compound 4; then compounds 2 and 1 (each within the scatter of the next); then compound 3.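

In this assay, the acetamido-type arm at this ring position turns out not to be weak in itself: tert-butyl on the saturated chain carbon bound to the carbonyl carbon of compound 3 gives the largest step in the series (a 32-fold lower number from compound 3 to compound 4 (1.50 log units; beyond the scatter)). With that addition, this arm surpasses both the methylcarbamoyl arm (a 10-fold lower number from compound 1 to compound 4 (1.00 log units; beyond the scatter)) and the (4-fluorophenyl)carbamoyl arm (a 7.9-fold lower number from compound 2 to compound 4 (0.90 log units; beyond the scatter)), which reverses the earlier order; enlarging the group changed little within the carbamoyl pair but a great deal here. Nothing available explains this gain.

The compounds shown leave open whether the gain depends on the tert-butyl group itself or whether a straight butyl chain or a cyclohexyl ring in its place would match it. Also open, on these data alone, is how a phenyl ring or a terminal carboxylic acid on this chain would fare.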